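Swapping Cyclohexyl for Phenyl: What Is Expected

A few compounds are considered here, and "the series" means these few. Any claim that something is new, unique, unknown or untested is made for them only; others in the source may bear on it.

Compound 1 `CC(C)c1nc(-c2ccccc2)cc(-c2ccc(C(F)(F)F)cc2)c1/C=C/[C@@H]1C[C@@H](O)CC(=O)O1`: 36 nM
Compound 2 `CC(C)c1nc(-c2ccc(F)cc2)c(/C=C/[C@@H]2C[C@@H](O)CC(=O)O2)c(C(C)C)n1`: 3 nM
Compound 3 `CC(C)c1nc(C2CCCCC2)nc(-c2ccc(F)cc2)c1/C=C/[C@@H]1C[C@@H](O)CC(=O)O1`: 1 nM

Of the compounds shown here, three have been measured in an assay for inhibition of 3-hydroxy-3-methylglutaryl-coenzyme A reductase (Rattus norvegicus); a lower number here means a stronger inhibitor, a higher number a weaker inhibitor. Compound 1 gives 36 nM, compound 2 gives 3 nM and compound 3 gives 1 nM. Compound 3 therefore stands lowest of the three numbers; its nearest neighbour is compound 2, and compound 1 lies furthest away. Among the compounds with values here, the only step between two compounds that differ in one place is a 3.0-fold lower number from compound 2 to compound 3 (0.48 log units; beyond the scatter).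

Compound 4 `CC(C)c1nc(-c2ccccc2)nc(-c2ccc(F)cc2)c1/C=C/[C@@H]1C[C@@H](O)CC(=O)O1` has not been measured. It differs from compound 3 in one place: phenyl in place of cyclohexyl on an aromatic carbon. Within the data shown here, no measured pair shows exactly this exchange. Compound 1 carries a phenyl group, but on a different core and with further changes beside it, so its value is not a guide to this step. Among the measured compounds shown here, the single measured step, from isopropyl to cyclohexyl on the same carbon, was modest, and the step to phenyl is therefore expected to be small as well, with no clear direction beyond the scatter. For compound 4 in this assay the estimate is 2 nM, within a range of 0.7 nM to 6 nM. The expected step is a 2.0-fold higher number from compound 3 to compound 4 (0.30 log units; within the scatter).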

Compound 4, half-maximal inhibitory concentration: 3 nM
Estimate against measurement, compound 4: 1.5-fold (0.18 log units) below; the range from low to high includes it.
By their numbers in this assay, from the lowest: compound 3; then compounds 2 and 4 (each within the scatter of the next); then compound 1.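

In this assay, the carbon between two ring nitrogen atoms now carries three measured groups on the shared core, and phenyl in place of cyclohexyl gives a 3.0-fold higher number from compound 3 to compound 4 (0.48 log units; beyond the scatter) with no change in the count of heavy atoms. Phenyl in place of isopropyl gives no change at the digits printed from compound 2 to compound 4 (within the scatter) even though the two groups differ in size by that count, so the number of heavy atoms alone does not order these three compounds, and the two six-membered rings of equal count are the ones that differ. Among these groups only cyclohexyl stands apart, by a modest margin, while the non-aromatic ring is the one feature that separates it from phenyl, and nothing in the data shown accounts for the difference.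

The compounds shown leave open how this carbon would respond to a group with a polar atom, such as an amine, a carboxylic acid or a pyridyl ring, or to a phenyl ring bearing a fluorine. They also leave open whether cyclohexyl would keep its small edge over phenyl on a different core, such as that of compound 1.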